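A few compounds are considered here, and "the series" means these few. Any claim that something is new, unique, unknown or untested is made for them only; others in the source may bear on it.

Three compounds share one core and differ in the group on the sulfonyl sulfur: compound 1 `O=C1C=CC(O)(c2cc3ccccc3n2S(=O)(=O)c2ccccc2)C=C1`, compound 2 `Cc1ccc(S(=O)(=O)n2c(C3(O)C=CC(=O)C=C3)cc3ccccc32)cc1` and compound 3 `COC(=O)CCc1ccc(S(=O)(=O)n2c(C3(O)C=CC(=O)C=C3)cc3ccccc32)cc1`. In a functional assay on HCT-116 cells (Homo sapiens) for inhibition, read by MTT assay, with a stated time of 72 h (a higher number here means that more compound is tolerated, a lower number that less compound is tolerated), compound 1 gives 30 nM and compound 3 gives 20 nM. Compound 2 gives < 10 nM, which is a limit of the assay and not a number. Its standing among the three therefore rests on (the limit of < 10 nM in this assay, at which 1 of the 3 values shown sits).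

The next compound is compound 4 `O=C1C=CC(O)(c2cc3ccccc3n2S(=O)(=O)c2cccnc2)C=C1`, with pyridin-3-yl in place of 4-methylphenyl on a sulfonyl sulfur. The measured steps cover only part of this change. Methyl in place of hydrogen on an aromatic carbon gave an at least 3.0-fold lower number from compound 1 to compound 2 (0.47 log units; beyond the scatter), and compound 4 carries no such methyl. The larger replacement, 2-(methoxycarbonyl)ethyl, gave a 1.5-fold lower number from compound 1 to compound 3 (0.18 log units; within the scatter), and the comparison of the two substituted compounds gave an at least 2.0-fold higher number from compound 2 to compound 3 (0.30 log units; that floor lies within the scatter). Among the measured compounds shown here, no measured step tests a nitrogen in this ring, so that part of the forecast is uncertain.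

Without the methyl, compound 4 is expected to resemble compound 1, which gives 30 nM. The expected change in this assay is therefore toward a higher number, estimated as an at least 3.0-fold higher number from compound 2 to compound 4 (0.47 log units; beyond the scatter). The estimate for compound 4 is 30 nM, with an expected range from 10 nM to 90 nM.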

Compound 4, concentration lethal to 50% of the cells: 290 nM
The estimate for compound 4 lay 9.7-fold (0.99 log units) below the measured number, and the stated range ends below it.
By their numbers in this assay, from the lowest: compounds 3 and 1 (each within the scatter of the next); then compound 4. At a limit, below all of these: compound 2.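

In this assay, among the compounds shown here, the group on the sulfonyl sulfur turns out to matter far more than the earlier compounds suggested: pyridin-3-yl in place of phenyl gives a 9.7-fold higher number from compound 1 to compound 4 (0.99 log units; beyond the scatter). For the compounds shown here, until now, the only replacements tested kept a ring of carbon only, and none of them gave a number beyond the scatter above that of compound 1, so compound 4, with one ring nitrogen, is the first compound here to lose ground against it; the comparison with the methyl-bearing ring is wider still, with pyridin-3-yl in place of 4-methylphenyl giving an at least 29-fold higher number from compound 2 to compound 4 (1.46 log units; beyond the scatter). Compound 2 stands at a limit, so that step is only a floor and its full size stays unknown: the limit of < 10 nM in this assay, at which 1 of the 4 values shown sits.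

Open, on these data alone, is whether the higher number belongs to this one placement of the ring nitrogen, a question that pyridin-2-yl or pyridin-4-yl on the sulfonyl sulfur would address. Also open, as far as these compounds go, is whether a methyl on the pyridin-3-yl ring would lower the number again, as methyl did on the phenyl ring, and whether another ring with a hetero atom, such as thiophen-2-yl, would behave like pyridin-3-yl.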